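The compounds below may be only part of what the source reports. "The series", "measured", "known", "first", "only" and "open" are said of these compounds alone.

Measured compounds:
Compound 1 `CCOc1nc(Cl)cc2nc(NCc3cc(C)c(-c4cn(C)nc4C)cn3)[nH]c12` gives 4200 nM in a functional assay on CHO cells for agonist activity at sphingosine 1-phosphate receptor 2 (Homo sapiens), read by fluorescence and calcium flux, with a stated time of 3 min; on this read-out higher numbers stand for weaker inhibition and lower numbers for stronger inhibition.
Compound 2 `CCOc1cc(NC(=O)NCc2cc(C)c(-c3cn(C)nc3C(F)(F)F)nn2)cc(C#N)n1` gives 5500 nM in this assay.
Compound 3 `CCOc1cc(NC(=O)NCc2cc(C)c(-c3cn(C)nc3C(F)(F)F)nn2)cc(C)n1` gives 4400 nM in this assay.

Compound 3 stands second highest of the three numbers, and its gaps to compound 1 and to compound 2 both lie within the scatter, so no order among them can be read. Compound 4 `CCOc1nc(C)cc(NC(=O)NCc2cc(C)c(-c3cn(C)nc3C(F)(F)F)nn2)c1Cl` differs from compound 3 by chloro in place of hydrogen on an aromatic carbon. Among the compounds with values here, the only measured step, a 1.3-fold lower number from compound 2 to compound 3 (0.10 log units; within the scatter), concerns a different group at a different place and does not bear on a chloro for hydrogen exchange, so nothing here predicts a shift. Compound 4 is therefore expected to show no change at the digits printed from compound 3 to compound 4 (within the scatter), no step beyond the scatter. The estimate for compound 4 in this assay is 4400 nM, within 1500 nM to 13000 nM.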

Compound 4, half-maximal inhibitory concentration: 4900 nM
The estimate for compound 4 lay 1.1-fold (0.05 log units) below the measured number; measured number inside the range.
By their numbers in this assay, from the lowest: compounds 1, 3, 4 and 2 (each within the scatter of the next).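

Chloro in place of hydrogen, on the aromatic carbon ortho to the ethoxy group and para to the methyl group, gives a 1.1-fold higher number from compound 3 to compound 4 (0.05 log units; within the scatter) in this assay, so this position accepts a chlorine with no readable change. The wider exchange of 2-cyano-6-ethoxypyridin-4-yl for 3-chloro-2-ethoxy-6-methylpyridin-4-yl gives a 1.1-fold lower number from compound 2 to compound 4 (0.05 log units; within the scatter), which is likewise no readable change. Nothing available explains this flat result.

Still open, as far as these compounds go, is whether an amine, a carboxylic acid or a longer chain at this position would move the number.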